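Swapping 3-chlorophenyl for 2-fluorophenyl on an amine nitrogen

The compounds below may be only part of what the source reports. "The series", "measured", "known", "first", "only" and "open" are said of these compounds alone.

- Compound 1 `Cc1ccccc1NNC(=O)c1cccc(NS(=O)(=O)c2cnc(O)nc2O)c1`: > 20000 nM (a limit, not a number)
- Compound 2 `O=C(NNc1ccccc1Cl)c1cccc(NS(=O)(=O)c2cnc(O)nc2O)c1`: 2090 nM
- Compound 3 `O=C(NNc1cccc(Cl)c1)c1cccc(NS(=O)(=O)c2cnc(O)nc2O)c1`: 7760 nM

Among the compounds with values here, in a functional assay on MDA-MB-231 cells (Homo sapiens) for antiproliferative activity, read by MTT assay, with a stated time of 24 h (on this read-out lower numbers stand for stronger inhibition and higher numbers for weaker inhibition), compound 3 gives 7760 nM, the higher of the two actual numbers so far; the other belongs to compound 2. Compound 1 reached only a limit, as the limit of > 20000 nM in this assay, at which 1 of the 3 values shown sits, records.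

The next molecule is compound 4 `O=C(NNc1ccccc1F)c1cccc(NS(=O)(=O)c2cnc(O)nc2O)c1`, which keeps the shared core but changes one group on an amine nitrogen: 2-fluorophenyl in place of 3-chlorophenyl on an amine nitrogen. In words, 2-fluorophenyl takes the place of 3-chlorophenyl.

The closest guide is compound 2, which also carries a 2-substituted phenyl. The step of a 3.7-fold higher number from compound 2 to compound 3 (0.57 log units; beyond the scatter) lies beyond the scatter and favours the 2-chlorophenyl group over the 3-chlorophenyl group. Compound 1 goes against any simple rule, though: it also has a 2-substituted phenyl, yet an at least 9.5-fold lower number from compound 1 to compound 2 (0.98 log units; beyond the scatter) shows that the chloro group did much better than the methyl group. Within the data shown here, no fluoro compound has been measured yet, so only part of the gain seen for compound 2 is assumed.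

A modest move towards stronger inhibition is therefore expected: a 2.2-fold lower number from compound 3 to compound 4 (0.35 log units; beyond the scatter). For compound 4 the estimated value is 3500 nM, with an expected range from 1300 nM to 11000 nM.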

Compound 4, half-maximal inhibitory concentration: > 20000 nM
Compound 4: no number, only a limit (the forecaster's own chance of this, stated with the estimate: 8%); at least 5.7-fold (0.75 log units) between middle value and limit.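

Compound 4 records no number in this assay, only a limit, and compound 1 ends the same way: the limit of > 20000 nM in this assay, at which 2 of the 4 values shown sit. At this position the identity of the atom on the ring matters a great deal, since fluoro in place of chloro gives an at least 9.5-fold higher number from compound 2 to compound 4 (0.98 log units; beyond the scatter), so a 2-substituted phenyl is not enough by itself: the 2-chlorophenyl group of compound 2 gives a number, while the 2-methylphenyl group of compound 1 and the 2-fluorophenyl group of compound 4 do not. The change from the 3-chlorophenyl group also goes the wrong way, with an at least 2.5-fold higher number from compound 3 to compound 4 (0.41 log units; beyond the scatter), so among these four compounds only the two that carry chloro, in either placement, reach a measurable number.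

From the compounds shown here alone, the step between compound 1 and compound 4 cannot be read because both values are limits, so the order of the methyl and fluoro groups stays open. Whether this advantage belongs to chloro alone, or would also hold for a larger group such as bromo or for a methoxy group on the same ring, is left open by the compounds shown.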